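This account rests on a few compounds, and the source may have more. Where it says the series, first, only, none or still open, it means among the compounds named here.

Three compounds share one core and differ only in the group on the saturated chain carbon bound to an oxygen on the aromatic ring. Compound 1 `COCOc1cc(=O)oc2cc(OCc3cccc(Cl)c3)ccc12` carries methoxy there, compound 2 `O=C(O)COc1cc(=O)oc2cc(OCc3cccc(Cl)c3)ccc12` carboxy and compound 3 `CN(C)C(=O)COc1cc(=O)oc2cc(OCc3cccc(Cl)c3)ccc12` dimethylcarbamoyl. In an assay on isolated protein (strain Sprague-Dawley) for inhibition of Amine oxidase [flavin-containing] A (Rattus norvegicus), read by spectrophotometry, with a stated time of 5 min, tested at 10 uM (on this read-out higher numbers stand for more inhibition at the one concentration tested (going by the name of the read-out) and lower numbers for less inhibition), compound 1 gives 23%, compound 2 gives 0% and compound 3 gives 10%. The step of a number 13 percentage points lower from compound 1 to compound 3 (beyond the scatter) is beyond the scatter, whereas the step of a number 10 percentage points higher from compound 2 to compound 3 (within the scatter) is within it, so compound 3 sits clearly under the highest number while it and compound 2 cannot be told apart. Compound 4 `O=C(COc1cc(=O)oc2cc(OCc3cccc(Cl)c3)ccc12)N1CCCCC1` keeps the carbonyl but changes the group on it: piperidin-1-yl in place of dimethylamino on a carbonyl carbon. Among the compounds with values here, only one measured step touches that carbonyl carbon, the change from hydroxy to dimethylamino, and it was a number 10 percentage points higher from compound 2 to compound 3 (within the scatter), within the scatter. Taking that as the only guide, the step to compound 4 is expected to be small, a number 2 percentage points higher from compound 3 to compound 4 (within the scatter). For compound 4 in this assay the estimate is 12%, with a range from 0% to 28%.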

Compound 4, a percentage reported as inhibition, at one concentration (the size of the read-out at that concentration, not a potency): 9%
The estimate for compound 4 lay 3 percentage points above the measured number; low and high end bracket the measured number.
By their numbers in this assay, from the lowest: compounds 2, 4 and 3 (each within the scatter of the next); then compound 1.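

In this assay, the ring of piperidin-1-yl on the carbonyl carbon cannot be told apart from the open dimethylamino, with a number 1 percentage points lower from compound 3 to compound 4 (within the scatter). Compound 4 also cannot be told apart from the carboxy compound, with a number 9 percentage points higher from compound 2 to compound 4 (within the scatter), yet it stays clearly under the methoxy compound, with a number 14 percentage points lower from compound 1 to compound 4 (beyond the scatter), so both amides shown fall short of compound 1. Nothing available explains these numbers.

With readings this close together at a single concentration, any real difference among these amides stays hidden. Still open, as far as these compounds go, is how the number would respond to morpholin-4-yl on the carbonyl carbon, to an amide that keeps its amide hydrogen, or to a longer chain in place of methoxy.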